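From compound 3 to compound 4: one added methoxy

The source may report more compounds than this note shows. Statements on the series, on what has been measured and on what is new or still open speak of the compounds shown alone.

Measured in a functional assay on K562 cells (Homo sapiens) for cytotoxicity, read by MTT assay, with a stated time of 48 h; a higher number here means a weaker inhibitor, a lower number a stronger inhibitor:
compound 1 `COc1ccc(-c2c(-c3cc(OC)c(OC)c(OC)c3)noc2N)cc1OC` gives 1270 nM
compound 2 `COc1ccc(-c2c(-c3cc(OC)c(OC)c(OC)c3)noc2NC(C)=O)cc1OC` gives 3710 nM
compound 3 `COc1ccc(-c2c(-c3cc(OC)c(OC)c(OC)c3)noc2N(C(C)=O)C(C)=O)cc1` gives 68 nM

Compound 3 has the lowest number of the three, and both others lie beyond the scatter from it. Compound 4 `COc1ccc(-c2c(-c3cc(OC)c(OC)c(OC)c3)noc2N(C(C)=O)C(C)=O)cc1OC` differs from it by methoxy in place of hydrogen on an aromatic carbon which turns 4-methoxyphenyl into 3,4-dimethoxyphenyl. Among the measured compounds shown here, the one measured step of a 2.9-fold higher number from compound 1 to compound 2 (0.47 log units; beyond the scatter) is acetyl in place of hydrogen on a nitrogen and does not bear on this change. For the measured compounds named here, the only hint comes from compound 1 at 1270 nM and compound 2 at 3710 nM which carry 3,4-dimethoxyphenyl but differ on the nitrogen. A modest rise in this assay is therefore expected, the estimated step being a 2.2-fold higher number from compound 3 to compound 4 (0.34 log units; beyond the scatter) with wide uncertainty. Compound 4 is estimated at 150 nM within a range of 40 nM to 900 nM for now.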

Compound 4, half-maximal inhibitory concentration: 4290 nM
For compound 4 the middle estimate is 29-fold (1.46 log units) below the measured one; measured number outside the range, above it.
By their numbers in this assay, from the lowest: compound 3; then compound 1; then compounds 2 and 4 (each within the scatter of the next).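

In this assay, the methoxy that turns 4-methoxyphenyl into 3,4-dimethoxyphenyl carries a large penalty (a 63-fold higher number from compound 3 to compound 4 (1.80 log units; beyond the scatter)), showing that this position is highly sensitive when diacetylamino is present. With 3,4-dimethoxyphenyl in place, the second acetyl makes no change beyond the scatter (a 1.2-fold higher number from compound 2 to compound 4 (0.06 log units; within the scatter)), and diacetylamino against amino gives only a modest rise (a 3.4-fold higher number from compound 1 to compound 4 (0.53 log units; beyond the scatter)), so diacetylamino alone does not confer the low number of compound 3. Nothing available accounts for these steps.

As far as these compounds go, it remains open whether hydroxyl, ethoxy or fluorine at this place would carry the same penalty, and whether the methoxy penalty also appears with amino or acetylamino on the core.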